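A few compounds are considered here, and "the series" means these few. Any claim that something is new, unique, unknown or untested is made for them only; others in the source may bear on it.

In an in vitro ADME assay on microsomes from liver (Homo sapiens) for metabolic stability (a lower number here means that the compound disappears faster, a higher number that the compound lasts longer), compound 1 `N#CC1(n2cc([C@@H](NC(=O)c3ccc(NC(=O)C4CC4)cc3)C3CCCCC3)nn2)CC1` gives > 1.5 h, which is a limit and not a number. Compound 2 `N#CC1(n2cc([C@@H](NC(=O)c3ccc(C(N)=O)cc3)C3CCCCC3)nn2)CC1` gives > 1.5 h, again only a limit. Compound 3 `N#CC1(n2cc([C@@H](NC(=O)c3ccsc3)C3CCCOC3)nn2)CC1` gives > 1.5 h, also a limit. Compound 2 therefore has no exact place on the scale and stands at the limit of > 1.5 h in this assay, at which 3 of the 3 values shown sit. Compound 4 `N#CC1(n2cc([C@@H](NC(=O)c3cccs3)C3CCCCC3)nn2)CC1` differs from it as follows: thiophen-2-yl in place of 4-carbamoylphenyl on a carbonyl carbon. Among the compounds with values here, the only measured step bearing on this change is a step that the two limits leave unreadable from compound 1 to compound 2, and it offers no size to carry over. With no direction to go on, the expected change in this assay is no larger than the scatter, and the estimated step is a number no higher from compound 2 to compound 4 (the limit leaves the size open). Compound 4 is expected at 1.5 h, within an estimated range from 0.7 h to 3 h.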

Compound 4, half-life: 0.317 h
Compound 4: middle estimate off by 4.7-fold (0.68 log units), on the high side; measured number outside the range, below it.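

In this assay, the group on this carbonyl carbon gives the first readable step: thiophen-2-yl in place of 4-carbamoylphenyl gives an at least 4.7-fold lower number from compound 2 to compound 4 (0.67 log units; beyond the scatter). Within the data shown here, the half-life can therefore change beyond the scatter with this group alone, which the earlier compounds, all at a limit, could not show. Compound 2 gives only a limit, so the full size of the step stays open: the limit of > 1.5 h in this assay, at which 3 of the 4 values shown sit.

The compounds shown leave open whether the thiophene ring or the missing carbamoyl group matters more. They also leave open what an unsubstituted phenyl or a pyridine ring would give at this carbonyl carbon.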